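Swapping methoxy for chloro: one step from one number

The compounds below may be only part of what the source reports. "The series", "measured", "known", "first", "only" and "open" are said of these compounds alone.

compound 1 `COc1ccc(SCc2ccc(C(=O)Nc3ccccc3N)cc2)cc1` – 2390 nM
compound 2 `Nc1ccccc1NC(=O)/C=C/c1ccc(CSCCc2ccccc2)cc1` – "not determined" (no result reported)

Within the data shown here, in a functional assay on HeLa cells (Homo sapiens) for antiproliferative activity, read by CCK-8 assay, with a stated time of 72 h (on this read-out lower numbers stand for stronger inhibition and higher numbers for weaker inhibition), compound 1 gives 2390 nM and is the only compound with a number. Compound 2 has no result, so no ranking is possible yet. Compound 3 `Nc1ccccc1NC(=O)c1ccc(CSc2ccc(Cl)cc2)cc1` has chloro in place of methoxy on an aromatic carbon, para to a large group (chloro in place of methoxy on an aromatic carbon). Among the measured compounds shown here, no measured step shows what this swap does, so no change beyond the usual scatter is expected, in either direction. The expected step is a 1.1-fold lower number from compound 1 to compound 3 (0.04 log units; within the scatter) and has no firm direction. Compound 3 is expected at 2200 nM within an estimated range of 800 nM to 6000 nM for now.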

Compound 3, half-maximal inhibitory concentration: 12700 nM
Estimate against measurement, compound 3: 5.8-fold (0.76 log units) below; the measured number lies above the stated range.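

In this assay, this position on the aromatic ring, para to a large group, is sensitive to what sits there: chloro in place of methoxy gives a 5.3-fold higher number from compound 1 to compound 3 (0.73 log units; beyond the scatter). Of these two groups, methoxy therefore goes with the stronger inhibition. No measurement at hand explains the difference. Open, on these data alone, is how other groups would fare at this place, such as a hydroxyl, an amine or a methyl. A single pair also cannot show whether the same swap would act alike on a different core.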